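A few compounds are considered here, and "the series" means these few. Any claim that something is new, unique, unknown or untested is made for them only; others in the source may bear on it.

In an ADME assay on Vero 76 cells (Chlorocebus sabaeus) for cytotoxicity, read by MTT assay, with a stated time of 96 h (on this read-out lower numbers stand for higher toxicity in this test and higher numbers for lower toxicity in this test), two compounds have been read so far. Compound 1 `Cc1ccc(NCc2cn(-c3ccccc3)nc2-c2ccccc2)cc1` gives > 100000 nM, which is a limit of the assay and not a number. Among the compounds with values here, compound 2 `Clc1ccc(NCc2cn(-c3ccccc3)nc2-c2ccc(Cl)cc2)cc1` gives 90000 nM, the only actual number available, so it has no measured neighbour against which it can be ranked. Compound 3 `Clc1ccc(NCc2cn(-c3ccccc3)nc2-c2ccccc2)cc1` follows from compound 2 by a single change, hydrogen in place of chloro on an aromatic carbon, para to a large group, so that 4-chlorophenyl becomes phenyl. Within the data shown here, no measured step covers this change, and the expectation in this assay is of no shift beyond the usual scatter. The estimated move is a 1.1-fold higher number from compound 2 to compound 3 (0.02 log units; within the scatter), and it starts from the reading of compound 2 at 90000 nM. The half-maximal cytotoxic concentration expected for compound 3 is 95000 nM, with an estimated range of 50000 nM to 150000 nM.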

Compound 3, half-maximal cytotoxic concentration: 65000 nM
Compound 3: the middle estimate sits 1.5-fold (0.16 log units) above what was measured, and the stated range covers the measured number.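

In this assay the change from 4-chlorophenyl to phenyl now has a measured size, a 1.4-fold lower number from compound 2 to compound 3 (0.14 log units; within the scatter), so at this place, on an aromatic carbon para to a large group, the exchange of chloro for hydrogen does not move the reading beyond the scatter. The other change, chloro in place of methyl on an aromatic carbon, gives an at least 1.5-fold lower number from compound 1 to compound 3 (0.18 log units; that floor lies within the scatter), which can be read only as a floor. Compound 1 stands at a limit of the assay and not at a number, so the true size of that step stays unknown: the limit of > 100000 nM in this assay, at which 1 of the 3 values shown sits.

As far as these compounds go, whether a methoxy, an amine or a carboxylic acid at this place would move the reading beyond the scatter remains open. So does whether the exchange of chloro for hydrogen would read the same on the other aromatic rings of the shared core.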